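Replacing a Phenol by a Chlorophenyl on the Shared Core

A few compounds are considered here, and "the series" means these few. Any claim that something is new, unique, unknown or untested is made for them only; others in the source may bear on it.

Of the compounds shown here, three of one series have been measured in a functional assay on KB cells (Homo sapiens) for cytotoxicity, read by MTT assay, with a stated time of 72 h; on this read-out higher numbers stand for an effect only at larger amounts of compound and lower numbers for an effect already at smaller amounts. Compound 1, `O=C1/C(=C\c2cc3ccccc3nc2Cl)c2ccccc2N1c1c(Cl)cccc1Cl`, gives 10 ug/mL in this assay. Compound 2, `O=C1/C(=C\c2ccc(O)cc2)c2ccccc2N1c1c(Cl)cccc1Cl`, gives 2 ug/mL. Compound 3, `O=C1/C(=C\c2cccc(Oc3ccccc3)c2)c2ccccc2N1c1c(Cl)cccc1Cl`, gives 5 ug/mL. Compound 2 stands lowest of the three numbers: its nearest neighbour is compound 3, whose number lies beyond the scatter above it, and the furthest is compound 1, also beyond the scatter.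

The step followed here leads from compound 2 to compound 4, `O=C1/C(=C\c2ccccc2Cl)c2ccccc2N1c1c(Cl)cccc1Cl`, which has not yet been measured in this assay. The change is 2-chlorophenyl in place of 4-hydroxyphenyl on a double-bonded chain carbon bound to a double-bonded ring carbon. The shared core and the dichlorophenyl group on the lactam nitrogen are kept.

Going by the values given here, no measured pair in this set shows this exact change. The two measured compounds that carry no hydroxyl both return higher numbers than compound 2: compound 1 gives 10 ug/mL and compound 3 gives 5 ug/mL. Compound 4 is therefore expected to give a somewhat higher number than compound 2, with a step from compound 2 to compound 4 estimated at a 2.5-fold higher number from compound 2 to compound 4 (0.40 log units; beyond the scatter), a rise that may just exceed the scatter. The estimate for compound 4 in this assay is 5 ug/mL, with a range from 2 ug/mL to 12 ug/mL.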

Compound 4, concentration for half-maximal effect: 5 ug/mL
For compound 4 middle estimate and measured number coincide at the digits printed; low and high end bracket the measured number.
By their numbers in this assay, from the lowest: compound 2; then compounds 3, 4 and 1 (each within the scatter of the next).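

In this assay, putting 2-chlorophenyl in place of 4-hydroxyphenyl on a double-bonded chain carbon bound to a double-bonded ring carbon gives a 2.5-fold higher number from compound 2 to compound 4 (0.40 log units; beyond the scatter) and so provides the first step read directly at this position, with the shared core and the dichlorophenyl group on the lactam nitrogen kept. Compound 2, the only one of the four that carries a hydroxyl, now stands alone at the lowest number, while compounds 3, 4 and 1, which carry none, form a run in which each lies within the scatter of the next, so three quite different groups at this position return closely spaced numbers. Nothing available here accounts for this rise.

The step removes the hydroxyl, brings in a chlorine and alters the substitution of the ring all at once, so the compounds shown cannot say which of these changes carries the difference. On these data alone, it also remains open how a plain phenyl ring would read at this position, and whether an amine or a carboxylic acid in place of the hydroxyl would stay near compound 2 or join the higher group.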